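Compound 1 to compound 3: swapping a four-membered ring

The source may hold more compounds than are shown below. What is called first, only, known or untested is meant among the compounds shown, and "the series" means these compounds.

- Compound 1 `Cc1cc(-c2ccnc3[nH]nc(C(F)(F)F)c23)cc(C2(CN)CCC2)c1`: 81%
- Compound 2 `NCC1(c2cccc(-c3ccnc4[nH]nc(C(F)(F)F)c34)c2)CCC1`: 81%

Going by the values given here, in an ADME assay on microsomes from liver (Homo sapiens), with a stated time of 30 min (on this read-out lower numbers stand for a less stable compound and higher numbers for a more stable compound), compound 1 stands level with compound 2, its only measured neighbour. Compound 3 `Cc1cc(-c2ccnc3[nH]nc(C(F)(F)F)c23)cc(C2(CN)COC2)c1` keeps the core of compound 1 but carries 3-(aminomethyl)oxetan-3-yl in place of 1-(aminomethyl)cyclobutyl on an aromatic carbon. Among the compounds with values here, the one measured step, no change at the digits printed from compound 1 to compound 2 (within the scatter), swaps methyl for hydrogen elsewhere, so it bears only indirectly on this change. Within the data shown here, no measurement yet tests the four-membered ring itself, so no shift beyond the scatter is expected, and the expected step is a number 2 percentage points higher from compound 1 to compound 3 (within the scatter). The estimate for compound 3 is 83%, with an expected range from 68% to 95%.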

Compound 3, percent of the compound remaining: 86%
For compound 3 the middle estimate is 3 percentage points below the measured one; low and high end bracket the measured number.
By their numbers in this assay, from the lowest: compounds 1, 2 and 3 (each within the scatter of the next).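

Placing 3-(aminomethyl)oxetan-3-yl in place of 1-(aminomethyl)cyclobutyl on the aromatic carbon gives a number 5 percentage points higher from compound 1 to compound 3 (within the scatter) in this assay. At this position, then, the compound tolerates an oxygen-containing four-membered ring in place of the all-carbon ring, with the extra hydrogen-bond acceptor leaving the read-out within its usual scatter. Nothing available explains this result.

The compounds shown leave open how an azetidine or a tetrahydropyran ring would read at this position. As far as these compounds go, a longer aminoethyl chain in place of the aminomethyl group also remains untested here.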